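A few compounds are considered here, and "the series" means these few. Any claim that something is new, unique, unknown or untested is made for them only; others in the source may bear on it.

In a functional assay on brain (Rattus norvegicus, strain Wistar) for inhibition (on this read-out lower numbers stand for stronger inhibition and higher numbers for weaker inhibition), the measured compounds are:
Compound 1 `CCCCCCCOc1ccc(-c2c(C)[nH]c(=O)n2C)cc1` gives 5700 nM
Compound 2 `CCCCCCCc1ccc(-c2c(C)[nH]c(=O)n2C2CCCCC2)cc1` gives 8700 nM

On these numbers compound 2 cannot be separated from compound 1, as the gap between them lies within the scatter. Compound 3 `CCCCCCCOc1ccc(-c2c(C)[nH]c(=O)n2C2CCCCC2)cc1` differs from compound 2 by heptyloxy in place of heptyl on an aromatic carbon, para to a large group (heptyloxy in place of heptyl on an aromatic carbon). Among the measured compounds shown here, no measured pair isolates this change, so no step beyond the scatter is expected in this assay in either direction. The expected 1.5-fold lower number from compound 2 to compound 3 (0.16 log units; within the scatter) is therefore small. For compound 3 the estimated value is 6000 nM with an expected range of 2000 nM to 18000 nM around it.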

Compound 3, half-maximal inhibitory concentration: 11600 nM
Beside the measured number, compound 3's estimate is 1.9-fold (0.29 log units) below it, within the range that was stated.
By their numbers in this assay, from the lowest: compounds 1, 2 and 3 (each within the scatter of the next, the first and the last beyond it).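

In this assay, heptyloxy in place of heptyl on an aromatic carbon, para to a large group, gives a 1.3-fold higher number from compound 2 to compound 3 (0.12 log units; within the scatter), so these two chains cannot be told apart at this position. With heptyloxy held fixed, cyclohexyl in place of methyl on the aromatic nitrogen gives a 2.0-fold higher number from compound 1 to compound 3 (0.31 log units; beyond the scatter), a modest step and the first single change shown to lie beyond the scatter. No evidence on the cause of either step is available. On these data alone, whether a shorter chain such as butyl or an amine on that aromatic carbon, or cyclopropyl on the aromatic nitrogen, would shift the number beyond the scatter remains open.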